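The compounds below may be only part of what the source reports. "The series", "measured", "known", "first", "only" and "open" are said of these compounds alone.

Measured so far in a functional assay on cells (Splenocyte, Mus musculus, strain BALB/c) for inhibition, read by scintillation counting and thymidine incorporation, with stated times of 48 h and 8 h; on this read-out lower numbers stand for stronger inhibition and higher numbers for weaker inhibition:
compound 1 `COc1cc(-c2noc(-c3ccc(N)cc3)n2)cc(OC)c1OC`: 1700 nM
compound 2 `COc1cc(-c2noc(-c3cccc(N)c3)n2)cc(OC)c1OC`: 5500 nM
compound 3 `CCc1ccc(-c2nc(-c3cc(OC)c(OC)c(OC)c3)no2)cc1`: > 50000 nM

The step of a 3.2-fold higher number from compound 1 to compound 2 (0.51 log units; beyond the scatter) is beyond the scatter. For compound 3 the reading is a limit only, not a number; compound 3 sits at the limit of > 50000 nM in this assay, at which 1 of the 3 values shown sits. The steps of an at least 29-fold higher number from compound 1 to compound 3 (1.46 log units; beyond the scatter) and an at least 9.0-fold higher number from compound 2 to compound 3 (0.95 log units; beyond the scatter) are therefore known only as lower bounds, and both put compound 3 as the weakest inhibitor of the three.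

Compound 4 `CCCCCCc1ccc(-c2nc(-c3cc(OC)c(OC)c(OC)c3)no2)cc1` is not yet measured. It differs from compound 3 by butyl in place of hydrogen on a saturated chain carbon, two bonds along the chain from an aromatic carbon. Among the compounds with values here, none of the measured steps lengthens an alkyl chain, so there is no direct precedent; the only anchor is that compound 3 itself is at the limit. Compound 4 is therefore expected to remain at the limit, a step of a number no higher from compound 3 to compound 4 (the limit leaves the size open), with an estimate of 50000 nM and a range of 15000 nM to 100000 nM.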

Compound 4, half-maximal inhibitory concentration: 22900 nM
Beside the measured number, compound 4's estimate is 2.2-fold (0.34 log units) above it, and the stated range covers the measured number.
By their numbers in this assay, from the lowest: compound 1; then compound 2; then compound 4. At a limit, above all of these: compound 3.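

In this assay, lengthening the ethyl of compound 3 to the hexyl of compound 4 gives a reading with a number (an at least 2.1-fold lower number from compound 3 to compound 4 (0.33 log units; beyond the scatter)), so this position tolerates a longer alkyl chain without loss. Hexyl still falls well short of amino on the aromatic carbon (a 13-fold higher number from compound 1 to compound 4 (1.13 log units; beyond the scatter)). The first step is only a lower bound, as compound 3 stands at a limit and not a number: the limit of > 50000 nM in this assay, at which 1 of the 4 values shown sits.

With only ethyl and hexyl shown, the course of the change with chain length between them stays open. So does whether octyl, or a hexyl chain ending in an amine or a carboxylic acid, would move the reading further.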